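The source may report more compounds than this note shows. Statements on the series, on what has been measured and on what is new or still open speak of the compounds shown alone.

Measured compounds:
compound 1 `Nc1ccccc1NC(=O)c1ccc(CSC(=S)N2CCN(c3ccc(F)cc3)CC2)cc1`, 18.8%
compound 2 `Cc1ccc(N2CCN(C(=S)SCc3ccc(C(=O)Nc4ccccc4N)cc3)CC2)cc1`, 33.4%

In a functional assay on MGC-803 cells (Homo sapiens) for antiproliferative activity, read by CCK-8 assay, with a stated time of 72 h, tested at 2 uM (on this read-out lower numbers stand for a weaker effect and higher numbers for a stronger effect at the one concentration tested), compound 2 gives 33.4%, the higher of the two numbers, and compound 1 gives 18.8%. Among the measured compounds shown here, the only measured step is a number 14.6 percentage points higher from compound 1 to compound 2 (beyond the scatter), which lies beyond the scatter and concerns a substituent on the aromatic ring attached to the ring nitrogen of the shared core.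

Compound 3 `Nc1ccccc1NC(=O)c1ccc(CSC(=S)N2CCN(Cc3cccnc3)CC2)cc1` has not yet been measured in this assay. It differs from compound 2 as follows: (pyridin-3-yl)methyl in place of 4-methylphenyl on an amine nitrogen in a ring. For the measured compounds named here, this change replaces the whole aromatic group on that ring nitrogen rather than a single substituent on it, so the step from compound 1 to compound 2 bears on it only loosely; no measured pair shows what exchanging the aryl group for a heteroaryl-methyl group does here. Going by the values given here, with only two numbers in hand, and those only modestly apart, a step in either direction of roughly the size already seen is plausible, and no direction is favoured.

Compound 3 is therefore expected to give about 26% in this assay, within a range from 9% to 45%. The step from compound 2 is expected to be a number 7.4 percentage points lower from compound 2 to compound 3 (within the scatter).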

Compound 3, a percentage reported as inhibition, at one concentration (the size of the read-out at that concentration, not a potency): 37.7%
Compound 3: the middle estimate sits 11.7 percentage points below what was measured; the measured number falls inside the stated range.
By their numbers in this assay, from the lowest: compound 1; then compounds 2 and 3 (each within the scatter of the next).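

In this assay, the place on the amine nitrogen of the six-membered ring tolerates the exchange of a whole group, not only of a single substituent on the aromatic ring. Putting (pyridin-3-yl)methyl in place of 4-methylphenyl keeps the count of heavy atoms and adds a hydrogen-bond acceptor, and the step is a number 4.3 percentage points higher from compound 2 to compound 3 (within the scatter), so this exchange leaves no readable difference. Put in place of 4-fluorophenyl, the same group gives a number 18.9 percentage points higher from compound 1 to compound 3 (beyond the scatter), which leaves compound 1 apart from the other two, while no finding in hand explains either step.

The compounds shown do not separate the effect of the methylene link from that of the nitrogen in the aromatic ring, as the two enter together, and a plain benzyl group at this place would bear on that question. They also leave open how a group without an aromatic ring, such as a cyclohexyl or an acetyl group, would fare here, and every reading so far rests on a single concentration in this assay.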